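Chloro for Fluoro on the Fused Ring: Expected Shift

A few compounds are considered here, and "the series" means these few. Any claim that something is new, unique, unknown or untested is made for them only; others in the source may bear on it.

Compound 1 `O=S(=O)(c1cccc(F)c1)c1cn(C2CCNC2)c2ccccc12` carries no substituent on the six-membered aromatic ring of its fused system, and in an assay on HeLa cells for displacement of a labelled ligand from 5-hydroxytryptamine receptor 6 (Homo sapiens), with a stated time of 2 h (on this read-out lower numbers stand for stronger inhibition and higher numbers for weaker inhibition), compound 1 gives 4.7 nM. Compound 2 `O=S(=O)(c1cccc(F)c1)c1cn(C2CCNC2)c2ccc(F)cc12` bears a fluoro there; in this assay compound 2 gives 9.6 nM, with a 2.0-fold higher number from compound 1 to compound 2 (0.31 log units; beyond the scatter). Compound 3 `CN1CCC(n2cc(S(=O)(=O)c3cccc(F)c3)c3cc(F)ccc32)C1` carries a methyl on the ring amine, and in this assay compound 3 gives 5 nM; a 1.9-fold lower number from compound 2 to compound 3 (0.28 log units; within the scatter). Compound 2 thus stands highest of the three numbers recorded, though its gap to compound 3 is within the scatter and only its gap to compound 1 is beyond it.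

Compound 4 `O=S(=O)(c1cccc(F)c1)c1cn(C2CCNC2)c2ccc(Cl)cc12` has not yet been measured. It differs from compound 2 by chloro in place of fluoro on an aromatic carbon. Within the data shown here, the one measured step at that same place is the change from hydrogen to fluoro between compound 1 and compound 2, which was modest; the change between compound 2 and compound 3 sits elsewhere and does not bear on a halogen swap. Trading one halogen for another is therefore expected to give at most a modest change in this assay, and quite possibly none beyond the scatter. Compound 4 is estimated at 10 nM, within 4 nM to 25 nM, which would mean an expected 1.0-fold higher number from compound 2 to compound 4 (0.02 log units; within the scatter).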

Compound 4, inhibition constant: 15 nM
Compound 4: middle estimate off by 1.5-fold (0.18 log units), on the low side; measured number inside the range.
By their numbers in this assay, from the lowest: compounds 1, 3, 2 and 4 (each within the scatter of the next, the first and the last beyond it).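

In this assay, exchanging fluoro for chloro on this aromatic carbon, para to a fused ring, does not separate the two halogens, since the step stays within the usual scatter (a 1.6-fold higher number from compound 2 to compound 4 (0.19 log units; within the scatter)). The earlier compounds had shown a step away from hydrogen at this place for fluoro alone, and chloro now gives one as well, again modest and beyond the scatter (a 3.2-fold higher number from compound 1 to compound 4 (0.50 log units; beyond the scatter)), so among the compounds shown, hydrogen at this place has the lower number against either halogen, and no compound goes against this. No supporting measurement is available to explain this behaviour of the position.

The compounds shown leave open whether a methoxy, a nitrile or an amine on this same aromatic carbon would stay as close to fluoro as chloro does, or would move the number further from that of compound 1. They also leave open whether methyl on the ring amine, seen here only together with fluoro on the aromatic carbon, would give a similar result together with chloro.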